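Notes on the step from compound 3 to compound 4

This account rests on a few compounds, and the source may have more. Where it says the series, first, only, none or still open, it means among the compounds named here.

Measured so far in an ADME assay on L132 cells (Homo sapiens) for cytotoxicity, read by MTT assay, with a stated time of 48 h (on this read-out higher numbers stand for weaker inhibition and lower numbers for stronger inhibition), each value being a limit of the assay and not a number:
compound 1 `C/C(=C\CC/C(C)=C/CC[C@@H]1[C@@]2(C)CCC(=O)C(C)(C)[C@H]2CC[C@@]1(C)O)CC/C=C(\C)C(=O)OCc1cn(-c2ccc(F)cc2)nn1`: > 150000 nM
compound 2 `C/C(=C\CC/C(C)=C/CC[C@@H]1[C@@]2(C)CCC(=O)C(C)(C)[C@H]2CC[C@@]1(C)O)CC/C=C(\C)C(=O)OCc1cn(-c2cccc(Br)c2)nn1`: > 150000 nM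
compound 3 `C/C(=C\CC/C(C)=C/CC[C@@H]1[C@@]2(C)CCC(=O)C(C)(C)[C@H]2CC[C@@]1(C)O)CC/C=C(\C)C(=O)OCc1cn(-c2ccc(Br)cc2)nn1`: > 150000 nM

Compound 3 has no number to its name, only its limit of > 150000 nM. The series as a whole reads as the limit of > 150000 nM in this assay, at which 3 of the 3 values shown sit.

Compound 4 `C/C(=C\CC/C(C)=C/CC[C@@H]1[C@@]2(C)CCC(=O)C(C)(C)[C@H]2CC[C@@]1(C)O)CC/C=C(\C)C(=O)OCc1cn(-c2ccc(C(C)(C)C)cc2)nn1` departs from compound 3 by one change: tert-butyl in place of bromo on an aromatic carbon. This is tert-butyl in place of bromo on an aromatic carbon, para to a large group, or 4-bromophenyl to 4-(tert-butyl)phenyl.

Among the measured compounds shown here, three measured steps bear on it. The closest is a step that the two limits leave unreadable from compound 1 to compound 3, since it also swaps the group on an aromatic carbon. The others are a step that the two limits leave unreadable from compound 1 to compound 2 and a step that the two limits leave unreadable from compound 2 to compound 3. None of them gives a size or a direction, so the data offer no measured guide to the effect of tert-butyl.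

In this assay no step beyond the scatter is expected, and no direction can be argued. The expectation rests on compound 3, whose limit is > 150000 nM. The expected step is a step that the limit leaves unreadable from compound 3 to compound 4, an estimate and not a reading. Another limit is the likeliest report. For compound 4 the estimated value is 170000 nM, with an expected range of 80000 nM to 300000 nM.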

Compound 4, half-maximal inhibitory concentration: 65800 nM
Beside the measured number, compound 4's estimate is 2.6-fold (0.41 log units) above it; the whole stated range lies above it.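

In this assay, among the compounds shown here, tert-butyl in place of bromo on an aromatic carbon, para to a large group, gives the first readable step: an at least 2.2-fold lower number from compound 3 to compound 4 (0.35 log units; beyond the scatter). The same holds when the 4-(tert-butyl)phenyl compound is set against the other two halogen-bearing compounds, with an at least 2.2-fold lower number from compound 2 to compound 4 (0.35 log units; beyond the scatter) and an at least 2.2-fold lower number from compound 1 to compound 4 (0.35 log units; beyond the scatter), whereas the steps among compound 1, compound 2 and compound 3 cannot be read. This place on the ring can therefore carry a change that registers in the read-out, although compound 4 is the only compound with a number and the rest of the series stays at a limit of the assay: the limit of > 150000 nM in this assay, at which 3 of the 4 values shown sit.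

From the compounds shown here alone, the true size of all three steps stays open, as each is reckoned from a limit and not from a number. Also open, going by these compounds, is whether the shift belongs to tert-butyl alone, or whether an isopropyl group, a methoxy group, an amine or a carboxylic acid at the same place would also bring the value down from the limit.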